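Fluoro to bromo on the sulfonyl aryl ring

A few compounds are considered here, and "the series" means these few. Any claim that something is new, unique, unknown or untested is made for them only; others in the source may bear on it.

- compound 1 `O=C(NS(=O)(=O)c1ccccc1)c1cccnc1` gives 9500 nM
- compound 2 `O=C(NS(=O)(=O)c1ccc(F)cc1)c1cncc(C(=O)NS(=O)(=O)c2ccc(F)cc2)c1` gives 1900 nM
- compound 3 `O=C(NS(=O)(=O)c1ccc(F)cc1)c1ccncc1` gives 9200 nM

In a functional assay on RAW264.7 cells (Mus musculus) for inhibition (on this read-out lower numbers stand for stronger inhibition and higher numbers for weaker inhibition), compound 3 stands at 9200 nM within the scatter of compound 1 and with a higher number than compound 2. The change to compound 4 `O=C(NS(=O)(=O)c1ccc(Br)cc1)c1ccncc1` puts bromo in place of fluoro on an aromatic carbon, para to a large group (bromo in place of fluoro on an aromatic carbon). Among the compounds with values here, no measured pair shows this exchange, so the expectation rests on compound 3 at 9200 nM as its only anchor, and no shift beyond the scatter is expected. The expected move is a 1.2-fold lower number from compound 3 to compound 4 (0.06 log units; within the scatter) as an estimate without a measured precedent. In this assay the estimate for compound 4 is 8000 nM with a range of 3500 nM to 18000 nM expected to hold the measurement.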

Compound 4, half-maximal inhibitory concentration: 5500 nM
The estimate for compound 4 lay 1.5-fold (0.16 log units) above the measured number, and the stated range covers the measured number.
By their numbers in this assay, from the lowest: compound 2; then compounds 4, 3 and 1 (each within the scatter of the next).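

In this assay, bromo in place of fluoro on an aromatic carbon, para to a large group, gives a 1.7-fold lower number from compound 3 to compound 4 (0.22 log units; within the scatter). Within the data shown here, this is the only measured exchange at this place, and it shows that the two halogens cannot be told apart here on this read-out, since the larger atom produces no shift beyond the scatter. No available measurement bears on the origin of this result.

From the compounds shown here alone, whether another group at this place, such as an amine, a carboxylic acid or a longer alkyl chain, would move the number beyond the scatter remains open. Also open, going by these compounds, is whether bromo in place of fluoro would give a similar step on the core of compound 2.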